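The source may hold more compounds than are shown below. What is called first, only, known or untested is meant among the compounds shown, and "the series" means these compounds.

Compound 1 `Cc1c(-n2c(N)c(C(N)=O)c(-c3ccccc3)c2-c2ccccc2)n(C)n(-c2ccccc2)c1=O` in a functional assay on the whole organism (strain Sprague-Dawley) for inhibition, with Rattus norvegicus as the target, read by paw edema, with stated times of 1 h and 4 h, at a dose of 70 mg/kg by the subcutaneous route; on this read-out higher numbers stand for more inhibition at the one dose given (going by the name of the read-out) and lower numbers for less inhibition: 62.6%.
Compound 2 `Cc1c(-n2c(-c3ccccc3)c(-c3ccccc3)c3c(N/N=C/c4ccccc4)ncnc32)n(C)n(-c2ccccc2)c1=O` in this assay: 48.4%.

Of the two numbers measured, compound 2 stands lowest; its nearest neighbour is compound 1, whose value lies higher by a gap beyond the scatter. Compound 3 `Cc1ccccc1Nc1ncnc2c1c(-c1ccccc1)c(-c1ccccc1)n2-c1c(C)c(=O)n(-c2ccccc2)n1C` has not been measured in this assay. It differs from compound 2 in one place: a group of 7 heavy atoms (7 carbon; one six-membered aromatic ring of carbon only) in place of a group of 8 heavy atoms (7 carbon, 1 nitrogen; one six-membered aromatic ring of carbon only), on a nitrogen on an aromatic ring. Among the compounds with values here, no step between two measured compounds that differ in one place is available, so nothing measured shows how this exchange acts on paw edema inhibition. The expected step is therefore a number 0.4 percentage points lower from compound 2 to compound 3 (within the scatter), a change no larger than the scatter in either direction, and it rests on the value of compound 2 alone. For compound 3 the estimated inhibition in this assay is 48%, with a range from 28% to 68%.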

Compound 3, a percentage reported as inhibition, in the whole organism at one dose (the size of the read-out at that dose, not a potency): 28%
Estimate against measurement, compound 3: 20 percentage points above; measured number inside the range.
By their numbers in this assay, from the lowest: compound 3; then compound 2; then compound 1.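

In this assay, within the data shown here, putting 2-methylphenyl on a nitrogen on an aromatic ring, in place of the group of 8 heavy atoms, gives a number 20.4 percentage points lower from compound 2 to compound 3 (beyond the scatter) and so shows for the first time that paw edema inhibition responds to what sits at this place. The change is a single exchange on an otherwise shared core: the group that leaves carries a double bond outside aromatic rings and a hydrogen-bond acceptor, and the group that enters carries neither. Nothing available accounts for the drop.

This one step cannot tell whether the loss of the nitrogen and double bond or the arrival of the methyl goes with the lower number. On these data alone, whether a plain phenyl or a benzyl group at this place would stand nearer compound 2 or compound 3 remains open.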